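The source may hold more compounds than are shown below. What is called first, only, known or untested is meant among the compounds shown, and "the series" means these compounds.

Measured in a functional assay on B16 cells (Mus musculus) for inhibition, with a stated time of 72 h; a higher number here means a weaker inhibitor, a lower number a stronger inhibitor:
- compound 1 `Cc1ccc(CN2CCCNC2=S)cc1`: 5100 nM
- compound 2 `COc1ccc(CN2CCCNC2=S)cc1`: 6100 nM
- compound 3 `CCc1ccc(CN2CCCNC2=S)cc1`: 1300 nM

Compound 3 has the lowest number of the three, and its steps to both others lie beyond the scatter. The next analogue, compound 4 `CC(C)c1ccc(CN2CCCNC2=S)cc1`, carries methyl in place of hydrogen on a saturated chain carbon bound to an aromatic carbon and a saturated chain carbon, which reads as ethyl to isopropyl: methyl in place of hydrogen on a saturated chain carbon bound to an aromatic carbon and a saturated chain carbon.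

Among the measured compounds shown here, the nearest precedent is the same kind of addition on a saturated chain carbon bound to an aromatic carbon: a 3.9-fold lower number from compound 1 to compound 3 (0.59 log units; beyond the scatter). This modest step favours the larger group. The other step to the ethyl compound is also modest: a 4.7-fold lower number from compound 2 to compound 3 (0.67 log units; beyond the scatter). By contrast, a 1.2-fold higher number from compound 1 to compound 2 (0.08 log units; within the scatter) stays within the scatter.

With a single precedent, the data do not show whether the gain continues. A smaller move in the same direction is expected in this assay, possibly still within the scatter. The expected step is a 1.4-fold lower number from compound 3 to compound 4 (0.16 log units; within the scatter). The estimate for compound 4 is 900 nM, with an expected range of 300 nM to 2800 nM.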

Compound 4, half-maximal inhibitory concentration: 800 nM
Compound 4: the middle estimate sits 1.1-fold (0.05 log units) above what was measured; the range from low to high includes it.
By their numbers in this assay, from the lowest: compounds 4 and 3 (each within the scatter of the next); then compounds 1 and 2 (each within the scatter of the next).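

Going from ethyl to isopropyl on this saturated chain carbon leaves compounds 3 and 4 indistinguishable in this assay (a 1.6-fold lower number from compound 3 to compound 4 (0.21 log units; within the scatter)), whereas the earlier methyl-in-place-of-hydrogen step, from methyl to ethyl, lay beyond the scatter (a 3.9-fold lower number from compound 1 to compound 3 (0.59 log units; beyond the scatter)). The isopropyl compound still stands apart from the methyl compound (a 6.4-fold lower number from compound 1 to compound 4 (0.80 log units; beyond the scatter)) and from the methoxy compound (a 7.6-fold lower number from compound 2 to compound 4 (0.88 log units; beyond the scatter)), so the separation seen with ethyl persists with the branched group. Nothing available explains these differences.

Still open, going by these compounds, is whether tert-butyl, a longer chain such as butyl, or an amine in place of isopropyl on the aromatic carbon would stay level with compounds 3 and 4 or move beyond the scatter. A single cell assay also leaves open whether this ordering holds in any other read-out.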